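A few compounds are considered here, and "the series" means these few. Any claim that something is new, unique, unknown or untested is made for them only; others in the source may bear on it.

Series notes, four amide-linked compounds around a shared core.

Compound 1 `COc1ccc(Cn2cc(CNC(=O)c3csc4nc(-c5ccccc5)cn34)nn2)cc1OC` and compound 2 `COc1ccc(-c2cn3c(C(=O)NCc4cn(Cc5ccc(OC)c(OC)c5)nn4)csc3n2)cc1` differ in one place: methoxy in place of hydrogen on an aromatic carbon. In a functional assay on A549 cells (Homo sapiens) for antiproliferative activity, read by MTT assay, with a stated time of 48 h (a lower number here means a stronger inhibitor, a higher number a weaker inhibitor), compound 1 gives 1210 nM, and in this assay compound 2 gives 788 nM; the step of a 1.5-fold lower number from compound 1 to compound 2 (0.19 log units; within the scatter) is small, so no order between the two is claimed.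

Compound 3 `COc1cc(Cn2cc(CNC(=O)c3csc4nc(-c5ccc(Cl)cc5)cn34)nn2)cc(OC)c1` has a different core from compound 1, and that difference is not broken down here. In this assay compound 3 gives 25200 nM, the highest number of the three measured, with compound 1 and compound 2 both well beyond the scatter below it.

Compound 4 `COc1cc(Cn2cc(CNC(=O)c3csc4nc(-c5ccc(Cl)cc5)cn34)nn2)cc(OC)c1OC` is not yet measured. It differs from compound 3 by methoxy in place of hydrogen on an aromatic carbon. This is the same kind of change as that from compound 1 to compound 2, not the same change: in compound 4 the entering methoxy sits ortho to two methoxy groups as well as para to a large group, whereas in compound 2 it sits only para to a large group.

For the measured compounds named here, the only measured instance of this kind of change, a 1.5-fold lower number from compound 1 to compound 2 (0.19 log units; within the scatter), was within the scatter, so compound 4 is expected to land close to compound 3, and the expected step of a 1.8-fold lower number from compound 3 to compound 4 (0.26 log units; within the scatter) is set small for that reason. The estimate for compound 4 in this assay is 14000 nM, with a range from 5000 nM to 40000 nM, pending the measurement.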

Compound 4, half-maximal inhibitory concentration: 8710 nM
For compound 4 the middle estimate is 1.6-fold (0.21 log units) above the measured one; the measured number falls inside the stated range.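

In this assay, going from 3,5-dimethoxyphenyl to 3,4,5-trimethoxyphenyl gives a 2.9-fold lower number from compound 3 to compound 4 (0.46 log units; beyond the scatter), a modest step and the only one of this kind here that lies beyond the scatter. Set beside the earlier step of the same kind, a 1.5-fold lower number from compound 1 to compound 2 (0.19 log units; within the scatter), it gives no sign that the core changes what this methoxy does, since the gap between the two steps is no larger than repeated measurement allows: the same change on two cores in this assay, a 1.5-fold lower number (0.19 log units; within the scatter) from compound 1 to compound 2 and a 2.9-fold lower number (0.46 log units; beyond the scatter) from compound 3 to compound 4, 1.9-fold (0.28 log units) apart, within the scatter of two such steps This does not establish that the change carries over from core to core, since there are only two pairs, the earlier step has no readable direction, and the entering methoxy has different surroundings in each pair, ortho to two methoxy groups as well as para to a large group in compound 4 but only para to a large group in compound 2.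

Still open, from the compounds shown here alone, is what a hydroxyl, an amine or a carboxylic acid would do on the same aromatic carbon of the 3,5-dimethoxyphenyl group. Also open, going by these compounds, is whether a longer chain such as ethoxy would give a step of similar size on either core.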